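Swapping an Aromatic Ring for an Ester Chain

The source may report more compounds than this note shows. Statements on the series, on what has been measured and on what is new or still open speak of the compounds shown alone.

Two close relatives have been measured in an assay on isolated protein for inhibition of Amine oxidase [flavin-containing] B (Homo sapiens), tested at 10 mM; a higher number here means a weaker effect of the compound at the concentration tested, a lower number a stronger effect. Compound 1 `COc1cccc(-c2csc(N/N=C/c3ccc4cc(OC)ccc4c3)n2)c1` gives 42% in this assay, and compound 2 `COc1ccc(-c2csc(N/N=C/c3ccc4cc(OC)ccc4c3)n2)cc1` gives 39.7%. Among the compounds with values here, the only step between them, a number 2.3 percentage points lower from compound 1 to compound 2 (within the scatter), is within the scatter, so the two numbers are indistinguishable. Compound 2 therefore holds the lowest of the two numbers, with compound 1 standing within the scatter of it.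

Compound 3 `CCOC(=O)Cc1csc(N/N=C/c2ccc3cc(OC)ccc3c2)n1` differs from compound 2 in one place: (ethoxycarbonyl)methyl in place of 4-methoxyphenyl on an aromatic carbon. Within the data shown here, no measured step bears directly on this change. Among the measured compounds shown here, the single step from compound 1 to compound 2 only moves a methoxy group around a six-membered ring that is itself removed here, and it was within the scatter. There is thus no measured basis for expecting a step of any size or direction in this assay, and a step beyond the scatter cannot be ruled out either; the estimated step from compound 2 to compound 3 is a number 7.7 percentage points lower from compound 2 to compound 3 (within the scatter). Compound 3 is expected to give about 32%, with a wide range from 8% to 56%.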

Compound 3, a percentage reported as inhibition, at one concentration (the size of the read-out at that concentration, not a potency): 90%
Compound 3: the middle estimate sits 58 percentage points below what was measured; the measured number lies above the stated range.
By their numbers in this assay, from the lowest: compounds 2 and 1 (each within the scatter of the next); then compound 3.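

Replacing the methoxyphenyl ring with (ethoxycarbonyl)methyl on the aromatic carbon next to the ring nitrogen gives a number 50.3 percentage points higher from compound 2 to compound 3 (beyond the scatter) in this assay and likewise a number 48 percentage points higher from compound 1 to compound 3 (beyond the scatter), so the effect of the compound at the concentration tested is clearly weaker with the chain. Moving the methoxy group around the ring had left the number within the scatter, whereas this result shows that the group at this position can matter a great deal when the whole ring is exchanged. The swap removes a six-membered aromatic ring and brings in an open chain with a double bond outside aromatic rings, and no measurement here explains why the number rises.

The compounds shown leave open whether losing the ring or adding the ester chain accounts for the step. An unsubstituted phenyl ring, a plain ethyl chain or a carboxylic acid in place of the ethyl ester at this position would help to separate those two parts of the change.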